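Opening the Urea Ring: Compound 3 Awaits Its Number

This account rests on a few compounds, and the source may have more. Where it says the series, first, only, none or still open, it means among the compounds named here.

Measured so far in a functional assay on A-431 cells (Homo sapiens) for antiproliferative activity, read by sulforhodamine B assay, with a stated time of 72 h; a lower number here means a stronger inhibitor, a higher number a weaker inhibitor:
Compound 1 `CN1CCN(C(=O)Nc2cc3c(Nc4ccc(F)c(Cl)c4)ncnc3cc2O[C@H]2CCOC2)CC1` gives 675 nM.
Compound 2 `O=C(Nc1cc2c(Nc3ccc(F)c(Cl)c3)ncnc2cc1O[C@H]1CCOC1)N1CCC(F)CC1` gives 3040 nM.

Compound 2 stands at the higher of the two numbers. Within the data shown here, the only step that connects it to a measured neighbour is a 4.5-fold higher number from compound 1 to compound 2 (0.65 log units; beyond the scatter), which places compound 2 as the weaker inhibitor of the pair by a margin beyond the scatter.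

Compound 3 `COC(=O)/C=C/CNC(=O)Nc1cc2c(Nc3ccc(F)c(Cl)c3)ncnc2cc1O[C@H]1CCOC1` differs from compound 2 by (3-(methoxycarbonyl)prop-2-en-1-yl)amino in place of 4-fluoropiperidin-1-yl on a carbonyl carbon. Among the measured compounds shown here, only one measured step touches this position, a 4.5-fold higher number from compound 1 to compound 2 (0.65 log units; beyond the scatter), and that step exchanged one six-membered ring for another, whereas compound 3 carries an open chain bearing a methoxycarbonyl group. The earlier step therefore offers only a gauge of how far this position can move this assay, and it was modest. Compound 3 is expected to settle close to compound 2, inside the span the measured pair covers. The expected step is a 1.5-fold lower number from compound 2 to compound 3 (0.18 log units; within the scatter). Compound 3 is estimated at 2000 nM, with a range from 500 nM to 8000 nM.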

Compound 3, half-maximal inhibitory concentration: 1410 nM
Estimate against measurement, compound 3: 1.4-fold (0.15 log units) above; the measured number falls inside the stated range.
By their numbers in this assay, from the lowest: compound 1; then compound 3; then compound 2.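

In this assay, among these compounds, the earlier compounds showed this position only as an exchange of one six-membered ring for another, so they could not say whether a ring on the carbonyl carbon is needed at all. Compound 3 answers that for this series: replacing 4-fluoropiperidin-1-yl with the open (3-(methoxycarbonyl)prop-2-en-1-yl)amino group gives a 2.2-fold lower number from compound 2 to compound 3 (0.33 log units; beyond the scatter) and so improves on that ring, while a 2.1-fold higher number from compound 1 to compound 3 (0.32 log units; beyond the scatter) leaves it short of the 4-methylpiperazin-1-yl ring, so the open chain falls between the two ring compounds and ring versus chain alone does not set the order. Nothing available here explains why the number moves in this way at this position.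

Compound 3 brings in the open chain, the double bond, the methoxycarbonyl group and the amide hydrogen in a single change, so the compounds shown cannot assign the gain over compound 2 to any one of these features. A carboxylic acid in place of the methoxycarbonyl group, or a saturated chain without the double bond, would begin to separate them.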